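The compounds below may be only part of what the source reports. "The series", "measured", "known", "first", "only" and "open" are said of these compounds alone.

Of the compounds shown here, three have been measured in a toxicity assay on Huh-7.5 cells (Homo sapiens) for inhibition, read by MTT assay, with a stated time of 96 h; on this read-out higher numbers stand for lower toxicity in this test and lower numbers for higher toxicity in this test. Compound 1 `CN(C)C1CCN(Cc2ccc(NC(=O)c3ccc(OCCCCl)c([N+](=O)[O-])c3)cc2C(F)(F)F)CC1` gives 5500 nM in this assay, and compound 2 `CN1CCN(Cc2ccc(NC(=O)c3ccc(OCCCCl)c(S(N)(=O)=O)c3)cc2C(F)(F)F)CC1` gives 5470 nM. Compound 3 `CC1CN(Cc2ccc(NC(=O)c3ccc(OCCCCl)c([N+](=O)[O-])c3)cc2C(F)(F)F)CC(C)O1` gives 2300 nM and so stands lowest of the three, beyond the scatter from both of the others. Among the measured compounds shown here, the one step that can be read directly, a 2.4-fold lower number from compound 1 to compound 3 (0.38 log units; beyond the scatter), shows that replacing a basic amine on the saturated chain carbon with the morpholine ring brought the number down.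

Compound 4 `CN1CCN(Cc2ccc(NC(=O)c3ccc(OCCCCl)c([N+](=O)[O-])c3)cc2C(F)(F)F)CC1` is compound 3 with one change: 4-methylpiperazin-1-yl in place of 2,6-dimethylmorpholin-4-yl on a saturated chain carbon bound to an aromatic carbon. The step from compound 1 to compound 3 bears on this, since it runs the other way, from the morpholine back to a basic nitrogen-containing ring, and compound 2, which carries the same 4-methylpiperazin-1-yl group on a different core, sits close to compound 1. Compound 4 is therefore expected to move upward by about a 2.2-fold higher number from compound 3 to compound 4 (0.34 log units; beyond the scatter), back toward the numbers of compound 1 and compound 2. The estimate for compound 4 in this assay is 5000 nM, within a range of 2500 nM to 10000 nM.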

Compound 4, half-maximal cytotoxic concentration: 6800 nM
Compound 4: middle estimate off by 1.4-fold (0.13 log units), on the low side, within the range that was stated.
By their numbers in this assay, from the lowest: compound 3; then compounds 2, 1 and 4 (each within the scatter of the next).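

In this assay the change on a saturated chain carbon bound to an aromatic carbon gives a 3.0-fold higher number from compound 3 to compound 4 (0.47 log units; beyond the scatter) and so sets 4-methylpiperazin-1-yl apart from 2,6-dimethylmorpholin-4-yl on one core, a contrast that earlier rested only on 4-(dimethylamino)piperidin-1-yl. The readings a 1.2-fold higher number from compound 1 to compound 4 (0.09 log units; within the scatter) and a 1.2-fold higher number from compound 2 to compound 4 (0.09 log units; within the scatter) show that neither exchanging the 4-(dimethylamino)piperidin-1-yl group for 4-methylpiperazin-1-yl nor putting nitro in place of sulfamoyl on an aromatic carbon moves the number beyond the scatter, which leaves compound 3 apart from the other three. No measurement is available to explain the gap between the two ring groups.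

Going by these compounds, whether an unsubstituted morpholine would read like compound 3 or like compound 4 remains open. So does the reading of a piperidine without the dimethylamino group at this position.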